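From a Cyanophenyl to a Cyanopyrazinyl Ether

The source may report more compounds than this note shows. Statements on the series, on what has been measured and on what is new or still open speak of the compounds shown alone.

compound 1 `CC(C)(C)OC(=O)N1CCC(O[C@H]2CC[C@H](Oc3ccc(S(C)(=O)=O)cc3F)CC2)CC1`: 61 nM
compound 2 `CC(C)(C)OC(=O)N1CCC(O[C@H]2CC[C@H](Oc3ccc(C#N)cc3)CC2)CC1`: 45 nM
compound 3 `Cc1nc(S(C)(=O)=O)ccc1O[C@H]1CC[C@H](OC2CCN(C(=O)OC(C)C)CC2)CC1`: 89 nM

In a functional assay on isolated protein for agonist activity at Glucose-dependent insulinotropic receptor (Rattus norvegicus), read by HTRF and cAMP accumulation (a lower number here means that less compound is needed, a higher number that more compound is needed for the effect), compound 2 gives 45 nM, the lowest of the three numbers, although compound 1 and compound 3 both sit within the usual scatter of it, so no real separation among the three is shown. Compound 4 `CC(C)(C)OC(=O)N1CCC(O[C@H]2CC[C@H](Oc3cnc(C#N)cn3)CC2)CC1` differs from compound 2 in one place: 5-cyanopyrazin-2-yl in place of 4-cyanophenyl on an oxygen on a saturated carbon. Among the measured compounds shown here, no pair of measured compounds shows a comparable change, so there is nothing to calibrate the step against. The nitrile is kept and the rest of the molecule is unchanged; the expectation is therefore a step from compound 2 to compound 4 of a 1.7-fold higher number from compound 2 to compound 4 (0.22 log units; within the scatter), that is, no shift beyond the scatter, with a slight lean toward a higher number. Compound 4 is expected to give 75 nM, within 25 nM to 220 nM.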

Compound 4, half-maximal effective concentration: 28.4 nM
The estimate for compound 4 lay 2.6-fold (0.42 log units) above the measured number, and the stated range covers the measured number.
By their numbers in this assay, from the lowest: compounds 4, 2, 1 and 3 (each within the scatter of the next, the first and the last beyond it).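

In this assay the change to 5-cyanopyrazin-2-yl from 4-cyanophenyl gives a 1.6-fold lower number from compound 2 to compound 4 (0.20 log units; within the scatter) and so shows no real shift. Among the compounds shown here, this is the first single-place step at this position, and it shows that the carbon-only aromatic ring can give way to one with 2 hetero atoms, with the nitrile kept, without a measurable loss. Nothing measured here offers an explanation for this result. Still open, going by these compounds, is what an amine or a carboxylic acid would do in place of the nitrile. Also open, on these data alone, is whether the same swap holds on a different core.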